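A few compounds are considered here, and "the series" means these few. Any claim that something is new, unique, unknown or untested is made for them only; others in the source may bear on it.

Measured so far:
Compound 1, `COc1ccc2c(c1)OC(c1cc(OC)c(OC)c(OC)c1)C(C(=O)OC(C)C)=C2`: in a functional assay for inhibition of nuclear factor NF-kappa-B complex (Homo sapiens) (a higher number here means a weaker inhibitor, a lower number a stronger inhibitor), compound 1 gives 11800 nM.
Compound 2, `COc1ccc2c(c1)OC(c1cc(OC)c(OC)c(OC)c1)C=C2`: in this assay compound 2 gives 17700 nM.

Among these two numbers compound 2 cannot be told apart from compound 1: the single measured step, a 1.5-fold higher number from compound 1 to compound 2 (0.18 log units; within the scatter), shows that removing the isopropoxycarbonyl group from the double-bonded ring carbon left the inhibition essentially unchanged.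

Compound 3, `COc1ccc2c(c1)OC(c1cc(OC)c(OC)c(OC)c1)C(/C=N/O)=C2`, returns to that same ring carbon and puts a different substituent there. The change is a group of 3 heavy atoms (1 carbon, 1 nitrogen, 1 oxygen; no ring) in place of a hydrogen atom, on a double-bonded ring carbon. Going by the values given here, the only measured step that bears on this change is the one from compound 1 to compound 2, in which the same ring carbon carried a substituent of a different kind, and that step stayed within the scatter. With a single such comparison, and with an entering group unlike the one that was removed, the expectation is modest: no shift beyond the scatter in either direction, so the step is estimated as a 1.3-fold lower number from compound 2 to compound 3 (0.10 log units; within the scatter). On that basis compound 3 is expected to give about 14000 nM in this assay, most likely between 5000 nM and 40000 nM.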

Compound 3, half-maximal inhibitory concentration: 14100 nM
For compound 3 the middle estimate is 1.0-fold (0.00 log units) below the measured one, within the range that was stated.
By their numbers in this assay, from the lowest: compounds 1, 3 and 2 (each within the scatter of the next).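

In this assay, a second and quite different substituent on the double-bonded ring carbon also fails to move the number: the group of 3 heavy atoms in place of hydrogen gives a 1.3-fold lower number from compound 2 to compound 3 (0.10 log units; within the scatter), and the same group in place of isopropoxycarbonyl gives a 1.2-fold higher number from compound 1 to compound 3 (0.08 log units; within the scatter). Going by these compounds alone, until now this position offered only one comparison, between hydrogen and an ester-bearing group; it now offers three substituents, one of them with a hydrogen-bond donor, and none stands apart from the others, so across these compounds the choice of substituent at this carbon makes no measurable difference. Nothing available explains why these three compounds read alike.

Going by these compounds, whether a carboxylic acid, an amine or a phenyl ring on this carbon would carry the number beyond the scatter remains open. Also open, on these data alone, is whether changing the methoxy groups elsewhere on the shared core would move the number more than any change seen so far at this position.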